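Shortening the Ester-Bearing Chain by One Carbon

The source may report more compounds than this note shows. Statements on the series, on what has been measured and on what is new or still open speak of the compounds shown alone.

Compound 1 `CCOC(=O)CCO/N=C(/c1ccc(OC)c(OC)c1OC)c1cccc2ccccc12` was tested in a functional assay on A549 cells (Homo sapiens) for inhibition, read by sulforhodamine B assay, with a stated time of 48 h (on this read-out higher numbers stand for weaker inhibition and lower numbers for stronger inhibition), where compound 1 gives 19600 nM. Compound 2 `COc1ccc(C(c2ccc(OC(C)CN(C)C)cc2)c2cccc3ccccc23)c(OC)c1OC` gives 11400 nM in this assay; these two numbers lie within the usual scatter of each other, so neither can be told apart from the other. Compound 3 `CCOC(=O)CO/N=C(/c1ccc(OC)c(OC)c1OC)c1cccc2ccccc12` differs from compound 1 by ethoxycarbonyl in place of (ethoxycarbonyl)methyl on a saturated chain carbon bound to an oxygen on an unsaturated carbon. Going by the values given here, no measured pair shows this change, so in this assay the shift is expected to stay within the scatter, with no clear direction, namely a 1.2-fold lower number from compound 1 to compound 3 (0.09 log units; within the scatter). Compound 3 is therefore estimated at 16000 nM, in a range from 5000 nM to 50000 nM.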

Compound 3, half-maximal inhibitory concentration: 6720 nM
The estimate for compound 3 lay 2.4-fold (0.38 log units) above the measured number, and the stated range covers the measured number.
By their numbers in this assay, from the lowest: compounds 3, 2 and 1 (each within the scatter of the next, the first and the last beyond it).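

In this assay, going by these compounds alone, replacing 2-(ethoxycarbonyl)ethoxy with (ethoxycarbonyl)methoxy gives a 2.9-fold lower number from compound 1 to compound 3 (0.46 log units; beyond the scatter) and is the first step in this set that can be read, so the length of this ester-bearing chain does affect the number, though on the evidence of a single pair. Nothing measured here gives a reason for the step. The compounds shown leave open whether the ester itself is needed, which a carboxylic acid or an amide at the end of this chain would test. Going by these compounds, how a longer chain would compare also remains open.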